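Fluoro in place of chloro: compound 3 to compound 4

The source may hold more compounds than are shown below. What is called first, only, known or untested is meant among the compounds shown, and "the series" means these compounds.

Compound 3 `O=C(N/N=C/c1c(-c2cc3ccc(Br)cc3oc2=O)[nH]c2ccccc12)c1ccccc1Cl` stands in a functional assay on MCF7 cells (Homo sapiens) for inhibition, read by MTT assay, with a stated time of 48 h (on this read-out higher numbers stand for weaker inhibition and lower numbers for stronger inhibition), only at a limit, giving > 192000 nM (the limit of > 192000 nM in this assay, at which 1 of the 3 values shown sits). For the measured compounds named here, compound 2 `O=C(N/N=C/c1c(-c2cc3ccc(Br)cc3oc2=O)[nH]c2ccccc12)c1ccccc1` gives 9100 nM in this assay, so an at least 21-fold higher number from compound 2 to compound 3 (1.32 log units; beyond the scatter) is the one measured step that touches this site. The change to compound 4 `O=C(N/N=C/c1c(-c2cc3ccc(Br)cc3oc2=O)[nH]c2ccccc12)c1ccccc1F` is fluoro in place of chloro on an aromatic carbon. Compound 1 `O=C(N/N=C/c1c(-c2cc3ccccc3oc2=O)[nH]c2ccccc12)c1ccccc1F` carries the same fluoro group but differs from compound 4 elsewhere in the shared core. In this assay compound 1 also sits only at a limit, > 200000 nM (the limit of > 200000 nM in this assay, at which 1 of the 3 values shown sits). Going by the values given here, no measured step compares fluoro with chloro directly, and with the starting point itself a limit, compound 4 is expected to remain near that limit, an estimated step of an at least 1.2-fold lower number from compound 3 to compound 4 (0.10 log units; that floor lies within the scatter). The estimate for compound 4 in this assay is 150000 nM, between 20000 nM and 400000 nM.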

Compound 4, half-maximal inhibitory concentration: > 200000 nM
Compound 4 ended at the assay's limit (the forecaster's own chance of this, stated with the estimate: 70%); at least 1.3-fold (0.12 log units) between middle value and limit.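

In this assay, fluoro in place of hydrogen on this aromatic carbon gives an at least 21-fold higher number from compound 2 to compound 4 (1.34 log units; beyond the scatter), so the large step seen with chloro is now seen with a second halogen. Compound 2, with hydrogen here, is the only compound shown with a value that is not a limit. The steps from compound 3 and from compound 1 to compound 4 cannot be read, and compound 4 is itself at a limit: the limit of > 200000 nM in this assay, at which 2 of the 4 values shown sit.

Any difference between fluoro and chloro at this position stays open. Also open, on these data alone, is whether an amine or a methoxy group here would give a value that is not a limit.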